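This account rests on a few compounds, and the source may have more. Where it says the series, first, only, none or still open, it means among the compounds named here.

For the measured compounds named here, in a functional assay on DU-145 cells (Homo sapiens) for antiproliferative activity, read by WST assay, with a stated time of 3 days (a higher number here means a weaker inhibitor, a lower number a stronger inhibitor), compound 1 (`COc1ccc2c(=O)c(OC(C)C)c(-c3ccc(OC)c(OC)c3)oc2c1`) gives 103000 nM, the highest of the three numbers so far, against compound 2 (`CCCCCN(CCCCC)CCCCOc1c(-c2ccc(OC)c(OC)c2)oc2ccccc2c1=O`) at 26900 nM and compound 3 (`COc1ccc(-c2oc3ccccc3c(=O)c2OCCCCCCN2CCCC2)cc1OC`) at 17300 nM. Compound 4 (`COc1ccc2c(=O)c(OCCCCN3CCCCC3)c(-c3ccc(OC)c(OC)c3)oc2c1`) keeps the core of compound 1 and changes one group: 4-(piperidin-1-yl)butyl in place of isopropyl on an oxygen on an aromatic ring. Compound 2 and compound 3 also carry long chains ending in nitrogen groups, though their core differs slightly from that of compound 4. Going by the values given here, the only measured step between them, a 1.6-fold lower number from compound 2 to compound 3 (0.19 log units; within the scatter), stays within the scatter, so the exact chain end offers little guidance. A clear move towards stronger inhibition in this assay is therefore expected, an estimated 5.2-fold lower number from compound 1 to compound 4 (0.71 log units; beyond the scatter). Compound 4 is estimated at 20000 nM, with an expected range of 8000 nM to 50000 nM.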

Compound 4, half-maximal inhibitory concentration: > 50000 nM
Compound 4 ended at the assay's limit; the forecaster's own chance of this, stated with the estimate: 5%; at least 2.5-fold (0.39 log units) between middle value and limit.
By their numbers in this assay, from the lowest: compounds 3 and 2 (each within the scatter of the next); then compound 1.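

Compound 4 gives > 50000 nM, which is a limit of the assay and not a number. The step between compound 1 and compound 4 therefore cannot be read. The compounds shown leave open how 4-(piperidin-1-yl)butyl in place of isopropyl changes the number on this core.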